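Piperidine to piperazine swap carried onto a second core

A few compounds are considered here, and "the series" means these few. Any claim that something is new, unique, unknown or untested is made for them only; others in the source may bear on it.

Compound 1 `COc1cc2c(Oc3ccc(NC(=O)c4nn(-c5ccccc5C(F)(F)F)c(=O)cc4C)cc3F)ccnc2cc1OCCCN1CCC(C)CC1` and compound 2 `COc1cc2c(Oc3ccc(NC(=O)c4nn(-c5ccccc5C(F)(F)F)c(=O)cc4C)cc3F)ccnc2cc1OCCCN1CCN(C)CC1` share one core; compound 3 `COc1ccc(-n2nc(C(=O)Nc3ccc(Oc4ccnc5cc(OCCCN6CCC(C)CC6)c(OC)cc45)c(F)c3)c(C)cc2=O)cc1` and compound 4 `COc1ccc(-n2nc(C(=O)Nc3ccc(Oc4ccnc5cc(OCCCN6CCN(C)CC6)c(OC)cc45)c(F)c3)c(C)cc2=O)cc1` share another. The two cores differ as counted in 4-methoxyphenyl in place of 2-(trifluoromethyl)phenyl on an aromatic nitrogen. In a functional assay on MKN-45 cells (Homo sapiens) for inhibition, read by MTT assay, with a stated time of 72 h (a higher number here means a weaker inhibitor, a lower number a stronger inhibitor), compound 1 gives 60 nM, and compound 2 gives 40 nM. In this assay compound 3 gives 400 nM, the highest of the three numbers; the move from the core of compound 1 to that of compound 3 reads a 6.7-fold higher number from compound 1 to compound 3 (0.82 log units; beyond the scatter).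

The change from compound 1 to compound 2 is 4-methylpiperazin-1-yl in place of 4-methylpiperidin-1-yl on a saturated chain carbon, three bonds along the chain from an oxygen on an aromatic ring. In this assay it made a 1.5-fold lower number from compound 1 to compound 2 (0.18 log units; within the scatter), a difference that cannot be told apart from repeat scatter. The same change, at the same place, is made from compound 3 to compound 4: 4-methylpiperazin-1-yl in place of 4-methylpiperidin-1-yl on a saturated chain carbon, three bonds along the chain from an oxygen on an aromatic ring. Compound 4 has not yet been measured in this assay.

Among the compounds with values here, the only measured instance of this change was within the scatter, so nothing in the data argues for a large step on the second core. Compound 4 is thus expected to show a 1.3-fold lower number from compound 3 to compound 4 (0.12 log units; within the scatter), resting on a 1.5-fold lower number from compound 1 to compound 2 (0.18 log units; within the scatter). The estimate for compound 4 in this assay is 300 nM, with the plausible range running from 150 nM to 700 nM. That estimate leans on a single precedent and should be held loosely.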

Compound 4, half-maximal inhibitory concentration: 1230 nM
Compound 4: middle estimate off by 4.1-fold (0.61 log units), on the low side; the measured number lies above the stated range.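

On the core of compound 3, 4-methylpiperazin-1-yl in place of 4-methylpiperidin-1-yl gives a 3.1-fold higher number from compound 3 to compound 4 (0.49 log units; beyond the scatter) in this assay, so the step does not carry over unchanged from the core of compound 1: the same change on two cores in this assay, a 1.5-fold lower number (0.18 log units; within the scatter) from compound 1 to compound 2 and a 3.1-fold higher number (0.49 log units; beyond the scatter) from compound 3 to compound 4, 4.6-fold (0.66 log units) apart, beyond the scatter of two such steps

Read along the other edge, 4-methoxyphenyl in place of 2-(trifluoromethyl)phenyl gives a 31-fold higher number from compound 2 to compound 4 (1.49 log units; beyond the scatter), so in this assay the two changes do not add independently across these four compounds: the same change on two cores in this assay, a 6.7-fold higher number (0.82 log units; beyond the scatter) from compound 1 to compound 3 and a 31-fold higher number (1.49 log units; beyond the scatter) from compound 2 to compound 4, 4.6-fold (0.66 log units) apart, beyond the scatter of two such steps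

Both gaps rest on the same four compounds and therefore count as one observation, which does not show which feature of the two aromatic groups goes with the difference, nor how the swap would behave on any further core.

The compounds shown leave open whether an unsubstituted phenyl on the aromatic nitrogen would follow the core of compound 1 or the core of compound 3 under the same swap, and whether a morpholine at the end of the propyl chain would split the same way. They also leave open whether the same gap would appear in a test without cells.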